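The source may report more compounds than this note shows. Statements on the series, on what has been measured and on what is new or still open speak of the compounds shown alone.

Compound 1 `CC(=O)NNC(=O)c1csc2ncc(-c3ccc(C)cc3)n12` gives 57300 nM in a functional assay on MCF7 cells (Homo sapiens) for antiproliferative activity, read by MTT assay, with a stated time of 72 h (on this read-out higher numbers stand for weaker inhibition and lower numbers for stronger inhibition), and compound 2 `COc1ccc(-c2cnc3scc(C(=O)NNC(C)=O)n23)cc1` gives 8360 nM there, while compound 3 `CCCC(=O)NNC(=O)c1csc2ncc(-c3ccc(OC)cc3)n12` gives 32800 nM there, which leaves compound 2 with the lowest number of the three. Compound 4 `CC(=O)NNC(=O)c1csc2ncc(-c3ccc(Br)cc3)n12` is not yet measured and differs from compound 2 by bromo in place of methoxy on an aromatic carbon in one change, bromo in place of methoxy on an aromatic carbon. The closest guide is the change at that same carbon, a 6.9-fold lower number from compound 1 to compound 2 (0.84 log units; beyond the scatter) when methoxy replaced methyl. The chain change, a 3.9-fold higher number from compound 2 to compound 3 (0.59 log units; beyond the scatter) at another place, bears less on it. Among the measured compounds shown here, no measured compound carries bromo. With a 6.9-fold lower number from compound 1 to compound 2 (0.84 log units; beyond the scatter) as the guide, a modest rise rather than a fall is expected in this assay when methoxy leaves. The expected size is a 2.6-fold higher number from compound 2 to compound 4 (0.42 log units; beyond the scatter) for this change. Compound 4 is estimated at 22000 nM with 7000 nM to 65000 nM as the expected range.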

Compound 4, half-maximal inhibitory concentration: 1830 nM
Beside the measured number, compound 4's estimate is 12-fold (1.08 log units) above it; the measured number lies below the stated range.
By their numbers in this assay, from the lowest: compound 4; then compound 2; then compounds 3 and 1 (each within the scatter of the next).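

At this aromatic carbon, methoxy is not the end of the trend: bromo brings a 4.6-fold lower number from compound 2 to compound 4 (0.66 log units; beyond the scatter) and, set against methyl, a 31-fold lower number from compound 1 to compound 4 (1.50 log units; beyond the scatter). The three groups tested here therefore run bromo, methoxy, methyl from lowest number to highest, and bromo reaches the lowest number with no hydrogen-bond acceptor, whereas methoxy has one. No measurement shown here explains why bromo has this effect. As far as these compounds go, whether chloro or iodo at this carbon would lower the number further stays open, as does whether the longer chain would raise the number alongside bromo as it did alongside methoxy.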